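A Naphthyl Swap on a Weakly Cytotoxic Aminopyrazole Core

This account rests on a few compounds, and the source may have more. Where it says the series, first, only, none or still open, it means among the compounds named here.

Compound 1, `COc1ccc(-c2cn(/N=C/c3cc4ccccc4nc3Cl)c(N)n2)cc1`: > 50000 nM
Compound 2, `COc1ccc(-c2cn(/N=C/c3cc4cc(C)ccc4nc3Cl)c(N)n2)cc1`: 23600 nM
Compound 3, `Cc1ccc2nc(Cl)c(/C=N/n3cc(-c4cccc5ccccc45)nc3N)cc2c1`: not yet measured

Of the compounds shown here, two have so far been tested in a functional assay on MDA-MB-231 cells (Homo sapiens) for cytotoxicity, read by MTT assay, with a stated time of 48 h; a lower number here means a stronger inhibitor, a higher number a weaker inhibitor. For compound 1 the assay reports only a limit, > 50000 nM, so no number is known for it. Among the measured compounds shown here, compound 2 gives 23600 nM, the only actual number in the set; the one other value is the limit of > 50000 nM in this assay, at which 1 of the 2 values shown sits. For the measured compounds named here, the single step measured so far, an at least 2.1-fold lower number from compound 1 to compound 2 (0.32 log units; beyond the scatter), concerns a methyl added to the bicyclic part of the shared core.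

Compound 3 changes a different part of the molecule: naphthalen-1-yl in place of 4-methoxyphenyl on an aromatic carbon. Going by the values given here, no measured step touches this position, and the one step on record involves another ring, so it gives no guide to direction. Without any bearing evidence, no movement beyond the usual scatter is expected, though the uncertainty is wide because the group swapped is large.

Compound 3 is therefore estimated at 22000 nM, with a plausible range from 7000 nM to 70000 nM. This estimate means a step of a 1.1-fold lower number from compound 2 to compound 3 (0.03 log units; within the scatter), which is expected to stay within the scatter.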

Compound 3, half-maximal inhibitory concentration: > 50000 nM
Compound 3 was reported as a limit; the forecaster's own chance of this, stated with the estimate: 30%; at least 2.2-fold (0.35 log units) between middle value and limit.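

Among the compounds shown here, this is the first measured change at the carbon of the five-membered aromatic ring that carries 4-methoxyphenyl, and it shows that this position is not indifferent in this assay: putting naphthalen-1-yl in its place gives an at least 2.1-fold higher number from compound 2 to compound 3 (0.32 log units; beyond the scatter), so the inhibitor becomes weaker. For compound 3, the value > 50000 nM is a limit and not a number, which leaves the full size of the step unknown. Compound 2 remains the only compound here with an actual number, and most of the set now sits at the top of the measurable range: the limit of > 50000 nM in this assay, at which 2 of the 3 values shown sit.

The swap removes the methoxy oxygen and adds a second aromatic ring in a single move, so the compounds shown leave open which of these two differences accounts for the step. A plain phenyl, a 4-hydroxyphenyl or a naphthalen-2-yl group on this same carbon, with the methyl of compound 2 kept in place, would help pull those two differences apart and show whether any group here can give a lower number than compound 2.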